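From 3,4-dichlorophenyl to phenyl at the assay limit

The compounds below may be only part of what the source reports. "The series", "measured", "known", "first", "only" and "open" are said of these compounds alone.

In a functional assay on HL-60 cells (Homo sapiens) for antiproliferative activity, read by MTT assay, with a stated time of 72 h (a higher number here means a weaker inhibitor, a lower number a stronger inhibitor), compound 1 `COc1ccc(-c2ncnn2-c2cc(OC)c(OC)c(OC)c2)cc1` gives 120 nM as its measured value. Compound 2 `COc1cc(-n2ncnc2-c2ccc(OC(F)(F)F)cc2)cc(OC)c1OC` gives > 10000 nM and this is a limit of the assay, not a number. Compound 3 `COc1cc(-n2ncnc2-c2ccc(Cl)c(Cl)c2)cc(OC)c1OC` gives > 10000 nM and this too is a limit. The place of compound 3 is therefore the limit of > 10000 nM in this assay, at which 2 of the 3 values shown sit, and no finer ranking is possible.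

Compound 4 `COc1cc(-n2ncnc2-c2ccccc2)cc(OC)c1OC` has phenyl in place of 3,4-dichlorophenyl on an aromatic carbon and is still unmeasured.

Within the data shown here, two measured steps bear on this change. The closer one is an at least 83-fold higher number from compound 1 to compound 3 (1.92 log units; beyond the scatter) and it swaps the group at this same place. The other is an at least 83-fold higher number from compound 1 to compound 2 (1.92 log units; beyond the scatter) and it puts trifluoromethyl in place of methyl on the oxygen of that same group. Going by these compounds, both are large, but both end at a limit, so their true sizes remain open. Compound 4 carries neither the 4-methoxyphenyl group of compound 1 nor the chlorine atoms of compound 3, so only a partial return is expected, and compound 1 with its 120 nM is not expected to be matched. The expected move is an at least 2.5-fold lower number from compound 3 to compound 4 (0.39 log units; beyond the scatter) and it is estimated to be modest, toward a lower number in this assay if a number appears at all. For compound 4 the estimate is 4000 nM with an expected range from 700 nM to 15000 nM as its two ends.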

Compound 4, half-maximal inhibitory concentration: > 10000 nM
Compound 4: a limit, no number; the forecaster's own chance of this, stated with the estimate: 45%; middle value at least 2.5-fold (0.39 log units) from the limit.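

In this assay, putting hydrogen in place of methoxy on the aromatic carbon gives an at least 83-fold higher number from compound 1 to compound 4 (1.92 log units; beyond the scatter). The earlier compounds shown here left room to blame the loss on something added, the chlorine atoms of compound 3 or the trifluoromethyl of compound 2, but the phenyl group of compound 4 carries neither of these, so the loss appears with nothing added at all. Among the compounds shown, only the 4-methoxyphenyl group of compound 1 goes with a measured number at this position; the steps from compound 2 and compound 3 to compound 4 cannot be read, and all three compounds sit at one mark: the limit of > 10000 nM in this assay, at which 3 of the 4 values shown sit.

The compounds shown leave open which part of the methoxy group counts, the oxygen or the methyl on it, a question that a hydroxy group, a methyl group or an amine at the same spot on the phenyl ring could help to settle. They also leave open how far compound 2, compound 3 and compound 4 lie past the limit, and so whether any order exists among them.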